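Benzyl substituent exchange in a weakly active amide pair

A few compounds are considered here, and "the series" means these few. Any claim that something is new, unique, unknown or untested is made for them only; others in the source may bear on it.

Measured so far:
compound 1: `CC(C)n1ncc2c(C(=O)NCc3cn(-c4ccc([N+](=O)[O-])cc4)nn3)cccc21`, > 40000 nM
compound 2: `CC(C)n1ncc2c(C(=O)NCc3cn(Cc4ccc(C#N)cc4)nn3)cccc21`, 39600 nM

In a functional assay on MGC-803 cells (Homo sapiens) for inhibition, read by MTT assay, with a stated time of 72 h (on this read-out lower numbers stand for stronger inhibition and higher numbers for weaker inhibition), compound 1 reaches only > 40000 nM, which is a limit of the assay and not a number. In this assay compound 2 gives 39600 nM. Going by the values given here, compound 2 therefore stands as the only real number in the set; the other entry is a limit. Among the compounds with values here, the single step, a number no higher from compound 1 to compound 2 (the limit leaves the size open), is bounded by the limit of > 40000 nM in this assay, at which 1 of the 2 values shown sits, so its size is not readable.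

Compound 3 `COc1ccc(Cn2cc(CNC(=O)c3cccc4c3cnn4C(C)C)nn2)cc1` is not yet measured. It differs from compound 2 in one place: methoxy in place of cyano on an aromatic carbon. Within the data shown here, no measured step bears on this change; the only step in the set concerns a different position and is open in size. Nothing in the data points to a shift of any direction, so no step beyond the scatter is expected. The expected step from compound 2 to compound 3 in this assay is a 1.0-fold higher number from compound 2 to compound 3 (0.00 log units; within the scatter). For compound 3 the estimate in this assay is 40000 nM, with a range from 12000 nM to 130000 nM. A limit rather than a number is also expected to be a frequent outcome for compound 3.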

Compound 3, half-maximal inhibitory concentration: > 40000 nM
Compound 3: no number, only a limit (the forecaster's own chance of this, stated with the estimate: 55%); the middle value lies on the limit itself.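

In this assay, exchanging 4-cyanobenzyl for 4-methoxybenzyl gives a number no lower from compound 2 to compound 3 (the limit leaves the size open), which is the first step shown at this position. Its size cannot be read, and the step between compound 1 and compound 3 cannot be read at all, as compound 3 carries a limit of the assay and not a number. Cyano and methoxy match in the counts of heavy atoms and hydrogen-bond acceptors, and with methoxy at this place the series gains no number lower than that of compound 2, so the values shown stay gathered at one end of the read-out: the limit of > 40000 nM in this assay, at which 2 of the 3 values shown sit.

The compounds shown carry only cyano and methoxy at this place, and they leave open whether an amine or a carboxylic acid there would give a readable number. Equally open, from the compounds shown here alone, is whether a longer chain in place of the 4-methoxybenzyl group would bring any member of the series clear of the limit.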